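Trifluoromethyl for propyl on the aromatic ring: compound 4

The source may hold more compounds than are shown below. What is called first, only, known or untested is meant among the compounds shown, and "the series" means these compounds.

Measured so far in an assay on CHO cells for displacement of a labelled ligand from prostaglandin E2 receptor EP2 subtype (Mus musculus), read by scintillation counting, with a stated time of 60 min; on this read-out higher numbers stand for weaker inhibition and lower numbers for stronger inhibition:
Compound 1 `O=C(O)CCCSCCN1C(=O)OC[C@@H]1/C=C/[C@@H](O)Cc1ccccc1` gives > 10000 nM, a limit of the assay.
Compound 2 `CCCc1cccc(C[C@H](O)/C=C/[C@H]2CSC(=O)N2CCSCCCC(=O)O)c1` gives > 10000 nM, a limit of the assay.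
Compound 3 `Cc1cccc(C[C@H](O)/C=C/[C@H]2CCC(=S)N2CCSCCCC(=O)O)c1` gives 1700 nM.

Compound 2 thus stands at the limit of > 10000 nM in this assay, at which 2 of the 3 values shown sit, with a bound and no number. Only compound 3 returns a number. Compound 4 `O=C(O)CCCSCCN1C(=O)SC[C@@H]1/C=C/[C@@H](O)Cc1cccc(C(F)(F)F)c1` differs from compound 2 by trifluoromethyl in place of propyl on an aromatic carbon. Within the data shown here, no measured pair shows this change, so no step size is known from the data. In this assay the change is expected to move the result little beyond the scatter, leaving compound 4 near the limit. Compound 4 is estimated at 8000 nM, between 2000 nM and 30000 nM. The expected step from compound 2 to compound 4 is an at least 1.2-fold lower number from compound 2 to compound 4 (0.09 log units; that floor lies within the scatter).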

Compound 4, inhibition constant: > 10000 nM
Compound 4 gave a limit, no number; the forecaster's own chance of this, stated with the estimate: 60%; middle value at least 1.2-fold (0.09 log units) from the limit.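

Compound 2 and compound 4 each give only a limit of the assay, so no step can be read for trifluoromethyl in place of propyl. The compounds shown leave open what this change does, as no one-place pair here returns two numbers.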